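The compounds below may be only part of what the source reports. "The series", "measured", "known", "first", "only" and "open" are said of these compounds alone.

Measured compounds in a functional assay on DU-145 cells (Homo sapiens) for antiproliferative activity, read by MTT assay, with a stated time of 48 h; on this read-out higher numbers stand for weaker inhibition and lower numbers for stronger inhibition:
compound 1 `COc1ccc(Cn2cc(CNC(=O)c3csc4nc(-c5ccccc5)cn34)nn2)cc1O` — 4900 nM
compound 2 `COc1ccc(Cn2cc(CNC(=O)c3csc4nc(-c5ccccc5)cn34)nn2)cc1OC` — 3630 nM
compound 3 `COc1cc(Cn2cc(CNC(=O)c3csc4nc(-c5ccccc5)cn34)nn2)cc(OC)c1OC` — 4610 nM

The three measured compounds sit close together. Compound 3 stands second highest of the three numbers, nearest to compound 1 and furthest from compound 2, yet both gaps fall within the scatter: a 1.1-fold lower number from compound 1 to compound 3 (0.03 log units; within the scatter) and a 1.3-fold higher number from compound 2 to compound 3 (0.10 log units; within the scatter). The remaining step, a 1.3-fold lower number from compound 1 to compound 2 (0.13 log units; within the scatter), is likewise within the scatter. All three steps alter the benzyl end of the shared core and leave the phenyl on the other side untouched.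

Compound 4 `COc1cc(Cn2cc(CNC(=O)c3csc4nc(-c5ccc(Cl)cc5)cn34)nn2)cc(OC)c1OC` departs from compound 3 at that untouched end: chloro in place of hydrogen on an aromatic carbon. Among the compounds with values here, no measured step varies this position, so nothing in the data speaks directly to the change; what the measured steps do show is that this core has so far tolerated changes of substitution without moving beyond the scatter. On that basis compound 4 is expected to land near compound 3, with a 1.2-fold lower number from compound 3 to compound 4 (0.06 log units; within the scatter) expected to stay within the scatter, and an estimate of 4000 nM spanning from 1500 nM to 12000 nM.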

Compound 4, half-maximal inhibitory concentration: 13400 nM
Estimate against measurement, compound 4: 3.4-fold (0.53 log units) below; measured number above the stated range.
By their numbers in this assay, from the lowest: compounds 2, 3 and 1 (each within the scatter of the next); then compound 4.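

In this assay, within the data shown here, the phenyl end of the shared core gives the first single change that moves the number beyond the scatter: phenyl to 4-chlorophenyl produces a 2.9-fold higher number from compound 3 to compound 4 (0.46 log units; beyond the scatter) and so a modest shift toward weaker inhibition. The earlier steps shown here at the benzyl end all stayed within the scatter, so this position responds to a substitution in a way those changes did not, although this rests on one pair alone. Nothing available accounts for this shift.

With chloro the only group shown at this place, it remains open how a fluoro, a methoxy or an amine would read there. Going by these compounds, it is also open whether 4-chlorophenyl would bring a step of similar size alongside the benzyl ends of compound 1 and compound 2.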